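Halogen swap on the isatin-like core of compound 1

A few compounds are considered here, and "the series" means these few. Any claim that something is new, unique, unknown or untested is made for them only; others in the source may bear on it.

Compound 1 `CN(C)CN1C(=O)C(=O)c2c(Br)cccc21` gives 67800 nM in an ADME assay on MCF-10A cells (Homo sapiens) for cytotoxicity, read by sulforhodamine B assay, with a stated time of 48 h (a lower number here means a stronger inhibitor of growth, a higher number a weaker inhibitor of growth), the lowest of the two numbers shown, while compound 2 `O=C1C(=O)N(CN(c2ccccc2)c2ccccc2)c2cccc(Br)c21` gives 85800 nM in this assay, a difference within the scatter. Among the compounds with values here, compound 3 `CN(C)CN1C(=O)C(=O)c2c(Cl)cccc21` carries chloro in place of bromo on an aromatic carbon, chloro in place of bromo on an aromatic carbon, the only change from compound 1. Within the data shown here, no comparable pair has been measured, so the expected step from compound 1 to compound 3 is a 1.2-fold higher number from compound 1 to compound 3 (0.07 log units; within the scatter), none beyond the scatter. Compound 3 is therefore expected to give 80000 nM in this assay, with a range from 35000 nM to 180000 nM.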

Compound 3, concentration for 50% growth inhibition: 82300 nM
Beside the measured number, compound 3's estimate is 1.0-fold (0.01 log units) below it; measured number inside the range.
By their numbers in this assay, from the lowest: compounds 1, 3 and 2 (each within the scatter of the next).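

Chloro in place of bromo on this aromatic carbon is the first single-place comparison in the series, and in this assay it gives a 1.2-fold higher number from compound 1 to compound 3 (0.08 log units; within the scatter) as the step. At this position, then, the two halogens are not told apart by this read-out. No measurement offers an explanation for this result.

The compounds shown leave open whether an amine or a methoxy group on the same aromatic carbon would give a step beyond the scatter. They also leave open how a hydrogen there would compare.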